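Azide for bromide on the side chain of compound 2

The source may report more compounds than this note shows. Statements on the series, on what has been measured and on what is new or still open speak of the compounds shown alone.

Going by the values given here, compound 2 `BrCCCCc1ccc(-c2ccc(-c3cccs3)s2)s1` is the only member of the set with a single number in an ADME assay on MDCK cells (Canis lupus familiaris) for cytotoxicity, read by MTT assay, with a stated time of 2 days (on this read-out higher numbers stand for lower toxicity in this test and lower numbers for higher toxicity in this test), where compound 2 gives 23800 nM. Compound 3 `BrCCCCc1ccc(-c2ccc(-c3ccc(CCCCBr)s3)s2)s1` carries a second 4-bromobutyl group; in this assay compound 3 reaches only the limit of > 200000 nM. Compound 1 `BrCCCCc1ccc(-c2ccc(-c3ccc(-c4ccc(CCCCBr)s4)s3)s2)s1` has no result in this assay: "not determined" (no result reported). Among the compounds with values here, the one measured step, an at least 8.4-fold higher number from compound 2 to compound 3 (0.92 log units; beyond the scatter), runs into the limit of > 200000 nM in this assay, at which 1 of the 3 values shown sits, and so gives only a lower bound for its true size.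

Compound 4 `[N-]=[N+]=NCCCCc1ccc(-c2ccc(-c3cccs3)s2)s1` differs from compound 2 by azido in place of bromo on a saturated chain carbon, four bonds along the chain from an aromatic carbon. Within the data shown here, no measured step concerns an exchange of this kind; the step from compound 2 to compound 3 adds a second 4-bromobutyl chain and says nothing about the end group of the single chain. Among the measured compounds shown here, with no bearing step, the expectation is a step not beyond the scatter, a 1.3-fold higher number from compound 2 to compound 4 (0.10 log units; within the scatter). Compound 4 is therefore estimated at 30000 nM, with a range from 8000 nM to 120000 nM.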

Compound 4, half-maximal cytotoxic concentration: > 200000 nM
Compound 4: no number, only a limit; the forecaster's own chance of this, stated with the estimate: 20%; middle value at least 6.6-fold (0.82 log units) from the limit.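

Exchange of the end group on the single chain, azido in place of bromo, gives an at least 8.4-fold higher number from compound 2 to compound 4 (0.92 log units; beyond the scatter) in this assay. Going by these compounds alone, the only earlier step added a second 4-bromobutyl chain, whereas this one shows that the read-out at this position responds to the end group alone, with the chain length and the core unchanged. The true size of the step remains unknown, and it can be read only as a lower bound: the limit of > 200000 nM in this assay, at which 2 of the 4 values shown sit.

Open, from the compounds shown here alone, is whether an amine or a carboxylic acid at the end of the 4-carbon-free position of the chain would also reach the limit or would give a single number. Equally open, going by these compounds, is whether a longer chain ending in bromo would stay close to the value of compound 2.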